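The source may hold more compounds than are shown below. What is called first, only, known or untested is meant among the compounds shown, and "the series" means these compounds.

Compound 1 `CC(C)N(Cc1cccc(OCCCCCC(=O)O)c1)C(=O)c1ccc(-c2ccoc2)cc1`, in an ADME assay on BJ cells (Homo sapiens) for cytotoxicity, read by CellTiter-Glo and resazurin assay, with a stated time of 72 h; a higher number here means that more compound is needed for the effect, a lower number that less compound is needed: > 26000 nM, a limit.
Compound 2 `CC(C)N(Cc1cccc(OCCCCCC(=O)O)c1)C(=O)c1ccc(-c2cccc(OCc3ccccc3)c2)cc1`: > 26000 nM, a limit.
Compound 3 `CC(C)N(Cc1cccc(OCCCCCC(=O)O)c1)C(=O)c1ccc(-c2ccc3[nH]ccc3c2)cc1`: > 26000 nM, a limit.

None of the three measured compounds shows toxicity within the tested range: all sit at the limit of > 26000 nM in this assay, at which 3 of the 3 values shown sit, so compound 3 stands at the limit, with no number to set it apart from the other two. The step that the two limits leave unreadable from compound 1 to compound 3 therefore cannot be sized. Compound 4 `CC(C)N(Cc1cccc(OCCCCCC(=O)O)c1)C(=O)c1ccc(-c2cccc(OC(F)(F)F)c2)cc1` differs from compound 3 by 3-(trifluoromethoxy)phenyl in place of 1H-indol-5-yl on an aromatic carbon. For the measured compounds named here, no measured step on this scaffold gives a readable size, so nothing points to a change beyond the scatter. Compound 4 is expected to remain at the limit, with an estimated step that the limit leaves unreadable from compound 3 to compound 4, and an estimated value of 30000 nM, from 15000 nM to 60000 nM.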

Compound 4, half-maximal effective concentration: > 26000 nM
Compound 4 ended at the assay's limit (the forecaster's own chance of this, stated with the estimate: 85%); the middle value is on the limit's open side.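

Compound 4 sits at the same limit as compounds 1, 2 and 3, so no step among these compounds can be read: the limit of > 26000 nM in this assay, at which 4 of the 4 values shown sit. In this assay the compounds shown leave open at what concentration any of them would show an effect.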